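This account rests on a few compounds, and the source may have more. Where it says the series, first, only, none or still open, it means among the compounds named here.

Of the compounds shown here, three from this series have been measured in an assay on HEK293 cells for displacement of a labelled ligand from Melanocortin receptor 4 (Homo sapiens); a higher number here means a weaker inhibitor, a lower number a stronger inhibitor. Compound 1 `COc1ccc(OC)c(CCC(=O)N2CCN(c3ccc(C(F)(F)F)cc3[C@@H](N)CC(C)C)CC2)c1` gives 2500 nM. Compound 2 `CC(C)C[C@H](N)c1cc(C(F)(F)F)ccc1N1CCN(C(=O)CCc2csc3ccccc23)CC1` gives 2300 nM. Between them the only change is a 1.1-fold lower number from compound 1 to compound 2 (0.04 log units; within the scatter). Compound 3 `CCN[C@H](c1cc(C(F)(F)F)ccc1N1CCN(C(=O)CCc2ccc(Cl)cc2Cl)CC1)C(C)CC` stands apart from both: in this assay compound 3 gives 92 nM, the lowest of the three numbers, and its gap to compound 2 and to compound 1 is beyond the scatter. Within the data shown here, compound 3 differs from compound 1 and compound 2 in several places at once, so the values show only that compound 3 is the strongest of the three, not which change brought it there.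

Compound 4 `CCC(C)[C@H](NC[C@@H]1CCCN1)c1cc(C(F)(F)F)ccc1N1CCN(C(=O)CCc2ccc(Cl)cc2Cl)CC1` is compound 3 with one change: pyrrolidin-2-yl in place of methyl on a saturated chain carbon bound to an amine nitrogen. Among the measured compounds shown here, no measured step touches this part of the molecule; the one step that is known, from compound 1 to compound 2, concerns the aryl group on the saturated chain and is within the scatter, so it gives no guidance here. With nothing to lean on, compound 4 is expected to stay close to compound 3, and the expected step is a 1.2-fold higher number from compound 3 to compound 4 (0.08 log units; within the scatter). In this assay compound 4 is estimated at 110 nM, with a range from 30 nM to 400 nM.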

Compound 4, inhibition constant: 64 nM
The estimate for compound 4 lay 1.7-fold (0.24 log units) above the measured number; the measured number falls inside the stated range.
By their numbers in this assay, from the lowest: compounds 4 and 3 (each within the scatter of the next); then compounds 2 and 1 (each within the scatter of the next).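

In this assay, putting pyrrolidin-2-yl in place of methyl on a saturated chain carbon bound to an amine nitrogen gives a 1.4-fold lower number from compound 3 to compound 4 (0.16 log units; within the scatter), so this assay does not separate the two compounds. Among these compounds, this is the first reading at this place, and it shows that the substituent can grow from a single carbon to five heavy atoms, gaining a five-membered non-aromatic ring, a hydrogen-bond donor, a hydrogen-bond acceptor and a defined stereocentre, without the number moving beyond the scatter. No measurement offered here accounts for this result, so the step stands as an observation alone.

The compounds shown leave open whether the ring nitrogen of the pyrrolidin-2-yl group has any bearing on the number, which a cyclopentyl group at the same place would test, and whether the opposite configuration at the new stereocentre would read the same. They also leave open how far this place accepts other groups, such as a piperidin-2-yl ring, a longer open chain ending in a primary amine, or a carboxylic acid.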